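Swapping the alkyne tip: hydroxymethyl to phenyl

This account rests on a few compounds, and the source may have more. Where it says the series, first, only, none or still open, it means among the compounds named here.

Compound 1 `CCCCC#Cc1cncc(OC[C@@H]2CCCN2C)c1`: 1.4 nM
Compound 2 `CN1CCC[C@H]1COc1cncc(C#CCO)c1`: 0.93 nM

In an assay on a protein complex for binding affinity to Neuronal acetylcholine receptor; alpha4/beta2 (Rattus norvegicus) (on this read-out higher numbers stand for weaker inhibition and lower numbers for stronger inhibition), compound 2 gives 0.93 nM, the lowest of the two numbers, while compound 1 gives 1.4 nM. Among the measured compounds shown here, the one step measured so far, a 1.5-fold lower number from compound 1 to compound 2 (0.18 log units; within the scatter), changed only the chain on the triple bond and stayed within the scatter. Compound 3 `CN1CCC[C@H]1COc1cncc(C#Cc2ccccc2)c1` carries phenyl in place of hydroxymethyl on a triple-bonded carbon. This change again touches only the group on the triple-bonded carbon, so a modest shift in this assay is expected, with some room for a weaker number since phenyl is a bulkier group than anything tried. Compound 3 is therefore expected at 3 nM, within 0.8 nM to 12 nM, a step of a 3.2-fold higher number from compound 2 to compound 3 (0.51 log units; beyond the scatter).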

Compound 3, inhibition constant: 0.51 nM
Compound 3: the middle estimate sits 5.9-fold (0.77 log units) above what was measured, and the stated range ends above it.
By their numbers in this assay, from the lowest: compounds 3, 2 and 1 (each within the scatter of the next, the first and the last beyond it).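

Phenyl, with its six-membered aromatic ring and no hydrogen-bond donor or acceptor, can replace hydroxymethyl on the triple-bonded carbon with no change beyond the scatter in this assay (a 1.8-fold lower number from compound 2 to compound 3 (0.26 log units; within the scatter)). Against butyl, the same ring gives the first step here that clears the scatter, though only a modest one (a 2.7-fold lower number from compound 1 to compound 3 (0.44 log units; beyond the scatter)). This place therefore accepts a ring as well as open chains, at least among these three compounds.

On these data alone, how an amine, a carboxylic acid or a phenyl ring bearing a fluorine atom would fare at this place remains open. Nothing shown here explains these numbers.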